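The source may report more compounds than this note shows. Statements on the series, on what has been measured and on what is new or still open speak of the compounds shown alone.

Of the compounds shown here, three built on one shared core have been tested in an ADME assay on cells (T-cell, Mus musculus, strain BALB/c) for cytotoxicity, read by MTT assay, with a stated time of 48 h; a lower number here means that less compound is tolerated, a higher number that more compound is tolerated. Compound 1 `COC(=O)c1cc(O)ccc1OC(=O)COc1cc(O)c2c(=O)cc(-c3ccccc3)oc2c1` gives 263000 nM. Compound 3 `COC(=O)c1c(Cl)cccc1OC(=O)COc1cc(O)c2c(=O)cc(-c3ccccc3)oc2c1` gives 366000 nM. For compound 2 `COC(=O)c1cc(Br)ccc1OC(=O)COc1cc(O)c2c(=O)cc(-c3ccccc3)oc2c1` the assay reports only a limit, > 450000 nM, so no exact number is known for it. Among the two plain numbers the single step is a 1.4-fold higher number from compound 1 to compound 3 (0.14 log units; within the scatter), which means compound 3 and compound 1 cannot be told apart on this evidence.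

Compound 4 `COC(=O)c1ccc(Br)cc1OC(=O)COc1cc(O)c2c(=O)cc(-c3ccccc3)oc2c1` has not yet been measured. It differs from compound 3 in one place:

a group of 11 heavy atoms (8 carbon, 2 oxygen, 1 bromine; one six-membered aromatic ring of carbon only) in place of a group of 11 heavy atoms (8 carbon, 2 oxygen, 1 chlorine; one six-membered aromatic ring of carbon only), on an oxygen next to a carbonyl group

For the measured compounds named here, two measured steps bear on this change. Swapping a hydroxy for a bromo on the aromatic ring gave an at least 1.7-fold higher number from compound 1 to compound 2 (0.23 log units; that floor lies within the scatter), and moving from the bromo-bearing ring to the chloro-bearing ring gave an at least 1.2-fold lower number from compound 2 to compound 3 (0.08 log units; that floor lies within the scatter). Both rest on a limit (the limit of > 450000 nM in this assay, at which 1 of the 3 values shown sits), and neither floor reaches beyond the scatter. For compound 4 the expected step is therefore a 1.1-fold higher number from compound 3 to compound 4 (0.04 log units; within the scatter), that is, no change in this assay that would stand out from repeat measurements. The estimated value for compound 4 is 400000 nM, expected to lie between 250000 nM and 640000 nM.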

Compound 4, half-maximal cytotoxic concentration: 326000 nM
Estimate against measurement, compound 4: 1.2-fold (0.09 log units) above; the range from low to high includes it.
By their numbers in this assay, from the lowest: compounds 1, 4 and 3 (each within the scatter of the next). At a limit, above all of these: compound 2.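

Exchanging the chlorine-bearing ring for a bromine-bearing one on the oxygen next to a carbonyl group gives a 1.1-fold lower number from compound 3 to compound 4 (0.05 log units; within the scatter) in this assay, so on this evidence the two halogen-bearing rings cannot be told apart. For the compounds shown here, the hydroxy-bearing ring cannot be separated from the bromine-bearing ring either, with a 1.2-fold higher number from compound 1 to compound 4 (0.09 log units; within the scatter), and this gives the first exact number for a ring that carries bromine. Rearranging the same ring atoms, so that only the place of the bromine differs, gives an at least 1.3-fold lower number from compound 2 to compound 4 (0.13 log units; that floor lies within the scatter), and this step is only a floor that rests on a limit: the limit of > 450000 nM in this assay, at which 1 of the 4 values shown sits.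

Going by these compounds, how much the place of the bromine matters stays open, as compound 2 has no exact number. The rings shown carry only a hydroxy, a chlorine or a bromine besides the methoxycarbonyl group, so it remains open whether an amine or a carboxylic acid on this ring would give a step beyond the scatter in this assay.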